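The source may hold more compounds than are shown below. What is called first, only, known or untested is meant among the compounds shown, and "the series" means these compounds.

Measured so far in an assay (Cricetulus griseus) for inhibition of aldehyde dehydrogenase, mitochondrial (Homo sapiens); a lower number here means a stronger inhibitor, a higher number a weaker inhibitor:
compound 1 `CCCCCCOc1ccc2c(=O)c(-c3ccc(O)cc3)coc2c1` gives 1500 nM;
compound 2 `O=c1c(-c2ccc(O)cc2)coc2cc(OCCCCCCCCCO)ccc12` gives 700 nM;
compound 3 `O=C(O)CCCCCCCOc1ccc2c(=O)c(-c3ccc(O)cc3)coc2c1` gives 40 nM.

Compound 3 stands lowest of the three, beyond the scatter from both others. Compound 4 `NCCCCOc1ccc2c(=O)c(-c3ccc(O)cc3)coc2c1` has not yet been measured. It differs from compound 3 in one place: amino in place of 3-carboxypropyl on a saturated chain carbon, four bonds along the chain from an oxygen on an aromatic ring. Within the data shown here, two measured steps bear on the end of this chain: a 38-fold lower number from compound 1 to compound 3 (1.57 log units; beyond the scatter) and an 18-fold lower number from compound 2 to compound 3 (1.24 log units; beyond the scatter), both large, both favouring the carboxy end over a plain or hydroxyl-ended chain. Because a 38-fold lower number from compound 1 to compound 3 (1.57 log units; beyond the scatter) was large and compound 4 gives up the carboxy end, a sizeable step back toward compound 1 is expected. Compound 4 is therefore estimated at 1000 nM, with a range from 300 nM to 4000 nM, an expected step of a 25-fold higher number from compound 3 to compound 4 (1.40 log units; beyond the scatter).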

Compound 4, half-maximal inhibitory concentration: 250 nM
Compound 4: middle estimate off by 4.0-fold (0.60 log units), on the high side; measured number outside the range, below it.
By their numbers in this assay, from the lowest: compound 3; then compound 4; then compound 2; then compound 1.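

In this assay, the amino-ended chain of compound 4 is shorter than the other chains, yet it still beats the plain chain (a 6.0-fold lower number from compound 1 to compound 4 (0.78 log units; beyond the scatter)) and the hydroxyl-ended chain (a 2.8-fold lower number from compound 2 to compound 4 (0.45 log units; beyond the scatter)). A carboxy end is therefore not the only chain end that gives a stronger inhibitor here, although it keeps the lead (a 6.3-fold higher number from compound 3 to compound 4 (0.80 log units; beyond the scatter)). Nothing available explains these differences.

Chain length and end group change together in compound 4, so their contributions remain unseparated. An amine on a longer chain, or a carboxylic acid on a chain as short as that of compound 4, would pull them apart.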